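Indane ether in place of methylphenyl on the piperidine oxygen

A few compounds are considered here, and "the series" means these few. Any claim that something is new, unique, unknown or untested is made for them only; others in the source may bear on it.

Compound 1 `Cc1ccccc1OC1CCN(c2ccc(-n3ccnc3)nn2)CC1`: 39 nM
Compound 2 `Cc1cccc(OC2CCN(c3ccc(-n4ccnc4)nn3)CC2)c1`: 251 nM

In an assay on microsomes from liver for inhibition of acyl-CoA desaturase 1 (Rattus norvegicus) (a lower number here means a stronger inhibitor, a higher number a weaker inhibitor), compound 2 gives 251 nM, the highest of the two numbers, while compound 1 gives 39 nM. Within the data shown here, the only step measured so far, a 6.4-fold higher number from compound 1 to compound 2 (0.81 log units; beyond the scatter), shows that moving the single methyl on this phenyl ring changes the number well beyond the scatter. Compound 3 `c1cc2c(c(OC3CCN(c4ccc(-n5ccnc5)nn4)CC3)c1)CCC2` differs from compound 2 by 2,3-dihydro-1H-inden-4-yl in place of 3-methylphenyl on an oxygen on a saturated carbon. Among the measured compounds shown here, no measured step matches this exchange directly; the one step at hand only shows that the aryl group attached to the oxygen matters. Since a fused five-membered ring is a larger change than moving a methyl, a shift beyond the scatter is expected, most likely downward toward the number of compound 1. The estimate for compound 3 in this assay is 70 nM (range 15 nM to 300 nM), which would be a step of a 3.6-fold lower number from compound 2 to compound 3 (0.55 log units; beyond the scatter).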

Compound 3, half-maximal inhibitory concentration: 10 nM
For compound 3 the middle estimate is 7.0-fold (0.85 log units) above the measured one; the whole stated range lies above it.
By their numbers in this assay, from the lowest: compound 3; then compound 1; then compound 2.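

In this assay, the exchange of 3-methylphenyl for 2,3-dihydro-1H-inden-4-yl is a 25-fold lower number from compound 2 to compound 3 (1.40 log units; beyond the scatter), and the exchange of 2-methylphenyl for the same group is a 3.9-fold lower number from compound 1 to compound 3 (0.59 log units; beyond the scatter). The earlier pair showed only that moving a methyl on the aryl group matters, whereas these steps show that a larger group, with an added five-membered non-aromatic ring of carbon only, gives a lower number than either methylphenyl group. No measurement at hand bears on the cause of this drop.

The compounds shown leave open whether the five-membered ring itself is needed, or whether a chlorine, a methoxy group or an amine on the phenyl ring would do as well. They also leave open how a five-membered ring containing an oxygen or a nitrogen would compare.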